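The source may report more compounds than this note shows. Statements on the series, on what has been measured and on what is new or still open speak of the compounds shown alone.

Going by the values given here, in a physicochemical assay for solubility, at pH 7.4 (a lower number here means a less soluble compound, a higher number a more soluble compound), compound 1 (`COc1c(NC(=O)c2ccc(C)c(N3C=C(C(=O)NCC(C)(C)C)NN3)c2)cc(C(C)(C)C)cc1NS(C)(=O)=O`) gives 0.1 ug/mL and compound 2 (`COc1c(NC(=O)c2ccc(C)c(N3C=C(C(=O)NCC(C)(C)O)NN3)c2)cc(C(C)(C)C)cc1NS(C)(=O)=O`) gives 2 ug/mL and so holds the higher of the two numbers measured so far. Among the compounds with values here, the single measured step is large and lies beyond the scatter: a 20-fold higher number from compound 1 to compound 2 (1.30 log units; beyond the scatter) when hydroxy takes the place of methyl on a saturated chain carbon bound to three saturated chain carbons. Compound 3 (`COc1c(NC(=O)c2ccc(C)c(N3C=C(C(=O)NCC(C)(C)CN(C)C)NN3)c2)cc(C(C)(C)C)cc1NS(C)(=O)=O`) differs from compound 2 at that same carbon, with (dimethylamino)methyl in place of hydroxy ((dimethylamino)methyl in place of hydroxy on a saturated chain carbon bound to three saturated chain carbons). Within the data shown here, no measured compound carries (dimethylamino)methyl, so the step from methyl to hydroxy is the only guide, and it tells nothing directly about this new group. It does show that a change at this carbon can move the number a long way. A further rise is therefore expected in this assay, though a smaller one than that large step, and the estimate is tentative: an expected 5.0-fold higher number from compound 2 to compound 3 (0.70 log units; beyond the scatter) in this read-out. Compound 3 is estimated at 10 ug/mL (expected range 2 ug/mL to 60 ug/mL).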

Compound 3, solubility: 13.9 ug/mL
For compound 3 the middle estimate is 1.4-fold (0.14 log units) below the measured one; the range from low to high includes it.
By their numbers in this assay, from the lowest: compound 1; then compound 2; then compound 3.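

The carbon bound to three saturated chain carbons proves able to carry more than one group that lifts the number in this assay: (dimethylamino)methyl in place of hydroxy gives a 7.0-fold higher number from compound 2 to compound 3 (0.84 log units; beyond the scatter) and so extends the rise that hydroxy began. Set against the methyl of compound 1, the dimethylamino group gives a 140-fold higher number from compound 1 to compound 3 (2.14 log units; beyond the scatter) and makes this the widest step seen at this site, while the order of the three compounds shows that the hydrogen-bond donor of hydroxy is not required for a high number here, since the entering group has 0 hydrogen-bond donors. No measurement is available that would explain the rise.

Since (dimethylamino)methyl brings 4 heavy atoms where hydroxy has 1, the compounds shown cannot separate the contribution of the nitrogen from that of the added carbons, and a plain ethyl or isopropyl group at this carbon would bear on that question. Also open, from the compounds shown here alone, is how a primary amine, a morpholine or a carboxylic acid at the same carbon would compare, and whether a longer chain between this carbon and the dimethylamino group would shift the number further.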